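The compounds below may be only part of what the source reports. "The series", "measured", "known", "first", "only" and "open" are said of these compounds alone.

Compound 3 `Cc1ccccc1-c1nnc(-c2sc(-c3cccnc3)nc2C)o1` is the point from which this step departs. In an ADME assay on PANC-1 cells (Homo sapiens) for cytotoxicity, read by MTT assay (on this read-out lower numbers stand for higher toxicity in this test and higher numbers for lower toxicity in this test), compound 3 gives > 100 ug/mL, which is a limit of the assay rather than a number. Its two companions stand at the same place. Going by the values given here, compound 1 `Cc1ccc(-c2nnc(-c3sc(-c4cccnc4)nc3C)o2)cc1` is the first of them; in this assay compound 1 gives > 100 ug/mL, again a limit. Compound 2 `COc1ccccc1-c1nnc(-c2sc(-c3cccnc3)nc2C)o1` is the second; in this assay compound 2 gives > 100 ug/mL, also a limit. Because every value sits at the limit of > 100 ug/mL in this assay, at which 3 of the 3 values shown sit, none of the three measured steps can be read: a step that the two limits leave unreadable from compound 1 to compound 2, a step that the two limits leave unreadable from compound 1 to compound 3 and a step that the two limits leave unreadable from compound 2 to compound 3 are all unreadable in size. Compound 4 `Cc1nc(-c2cccnc2)sc1-c1nnc(-c2ccccc2Cl)o1` is the next member. Compared with compound 3, the difference is chloro in place of methyl on an aromatic carbon. The step that bears most closely on this change is a step that the two limits leave unreadable from compound 2 to compound 3, a swap of one small group for another on an aromatic carbon, yet it shows only that both partners stay beyond the limit. With no readable step among the three measured compounds, no shift beyond the scatter is expected for compound 4. The step from compound 3 to compound 4 is therefore expected to be a step that the limit leaves unreadable from compound 3 to compound 4. For compound 4 the estimate in this assay is 150 ug/mL, with a range from 100 ug/mL to 300 ug/mL, and the assay will most likely again report only a limit.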

Compound 4, half-maximal cytotoxic concentration: > 100 ug/mL
Compound 4: only a limit was reported; the forecaster's own chance of this, stated with the estimate: 85%; the middle value lies beyond the limit too.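

No step from compound 1, compound 2 or compound 3 to compound 4 can be read in size, because all four values stand at one and the same limit: the limit of > 100 ug/mL in this assay, at which 4 of the 4 values shown sit.

The compounds shown leave open how far each of the four lies past that limit in this assay, and so whether 2-chlorophenyl, 2-methylphenyl, 2-methoxyphenyl and 4-methylphenyl differ at all.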